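The source may report more compounds than this note shows. Statements on the series, on what has been measured and on what is new or still open speak of the compounds shown alone.

Compound 1 `C=C1CC[C@@H]2[C@](C)(CO)[C@H](O)CC[C@@]2(C)[C@@H]1CCC1=CCOC1=O` is the parent of this small series. In a functional assay on NIH3T3 cells (Mus musculus) for inhibition, read by MTT assay, with a stated time of 72 h (a lower number here means a stronger inhibitor, a higher number a weaker inhibitor), compound 1 gives 176000 nM, the highest number of the three measured compounds, so it is the weakest inhibitor among them. Compound 2 `C=C1CC[C@H]2[C@@](C)(CC[C@@H](O)[C@@]2(C)C(=O)OC)[C@@H]1CCC1=CCOC1=O` carries methoxycarbonyl in place of hydroxymethyl on a saturated ring carbon and gives 60600 nM in this assay, a step of a 2.9-fold lower number from compound 1 to compound 2 (0.46 log units; beyond the scatter). Compound 3 `C=C1CC[C@H]2[C@@](C)(CC[C@@H](O)[C@@]2(C)C(=O)OCc2ccccc2)[C@@H]1CCC1=CCOC1=O` carries benzyloxycarbonyl in the same place and gives 37900 nM, a step of a 4.6-fold lower number from compound 1 to compound 3 (0.67 log units; beyond the scatter); the further step a 1.6-fold lower number from compound 2 to compound 3 (0.20 log units; within the scatter) from phenyl in place of hydrogen stays within the scatter.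

Compound 4 `C=C1CC[C@@H]2[C@](C)(CO)[C@H](O)CC[C@@]2(C)[C@@H]1C/C=C1\C=COC1=O` is not yet measured. It differs from compound 1 by a group of 7 heavy atoms (5 carbon, 2 oxygen; one five-membered non-aromatic ring with 1 hetero atom) in place of a group of 7 heavy atoms (5 carbon, 2 oxygen; one five-membered non-aromatic ring with 1 hetero atom), on a saturated chain carbon bound to a saturated ring carbon. This change sits on a saturated chain carbon bound to a saturated ring carbon, far from the hydroxymethyl where compounds 2 and 3 were varied, so none of the three measured steps bears on it. Within the data shown here, with no comparable step available, the expected change from compound 1 to compound 4 is none beyond the scatter, and the estimated step is a 1.2-fold lower number from compound 1 to compound 4 (0.07 log units; within the scatter). Compound 4 is therefore expected to give about 150000 nM in this assay, within a range from 50000 nM to 450000 nM.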

Compound 4, half-maximal inhibitory concentration: "not active" (no number reported)
For compound 4 the study gives words and no number; no gap can be computed for the estimate.
By their numbers in this assay, from the lowest: compounds 3 and 2 (each within the scatter of the next); then compound 1.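

In this assay compound 4 is reported only in words, as not active, so no step can be read between it and compound 1, which gives 176000 nM. Nothing shown here explains this result. The compounds shown leave open how large the difference between compound 1 and compound 4 is, and whether the same change on a saturated chain carbon bound to a saturated ring carbon would matter alongside the groups of compound 2 or compound 3.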